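A few compounds are considered here, and "the series" means these few. Any claim that something is new, unique, unknown or untested is made for them only; others in the source may bear on it.

Measured so far:
- Compound 1 `COc1ccc(/C=C2/CN(C)/C(=N/c3ccc(C(C)(C)C)cc3)S2)cc1`: 23500 nM
- Compound 2 `COc1ccc(/C=C2\S/C(=N\c3ccc(Cl)cc3)N(C)C2=O)cc1`: > 100000 nM

Going by the values given here, in an ADME assay on TERT-RPE1 cells (Homo sapiens) for cytotoxicity, read by MTT assay, with a stated time of 72 h (a lower number here means a stronger inhibitor, a higher number a weaker inhibitor), compound 1 gives 23500 nM, the only exact number available. Compound 2 reads > 100000 nM, which is a limit of the assay and not a number.

Compound 3 `COc1ccc(/C=C2/CN(C)/C(=N/c3ccc(OC)cc3)S2)cc1` keeps the core of compound 1 and alters one group, with methoxy in place of tert-butyl on an aromatic carbon. Among the compounds with values here, no pair of measured compounds tests this kind of swap, so the only anchor is compound 1 at 23500 nM. A modest shift is expected, leaning toward a higher number and thus weaker cell toxicity, and it may not clear the usual scatter: a 1.7-fold higher number from compound 1 to compound 3 (0.23 log units; within the scatter). The estimated value for compound 3 is 40000 nM, with an expected range from 14000 nM to 100000 nM.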

Compound 3, half-maximal inhibitory concentration: 65900 nM
Compound 3: the middle estimate sits 1.6-fold (0.22 log units) below what was measured, within the range that was stated.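

Replacing tert-butyl with methoxy on an aromatic carbon changes the result in this assay, giving a 2.8-fold higher number from compound 1 to compound 3 (0.45 log units; beyond the scatter). Going by these compounds alone, until now no two measured compounds differed in only one place, so this is the first sign that this position alone can shift toxicity to these cells, with the higher number meaning weaker toxicity. A single swap cannot separate the loss of the carbon atoms of tert-butyl from the arrival of the oxygen of methoxy, since both happen at once.

Within the data shown here, compound 2 is a limit and not a number, and it offers no step that can be read: the limit of > 100000 nM in this assay, at which 1 of the 3 values shown sits. On these data alone, whether an amine or a carboxylic acid at this same position would move the number further, and in which direction, remains open.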